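This account rests on a few compounds, and the source may have more. Where it says the series, first, only, none or still open, it means among the compounds named here.

Values measured in a functional assay on MCF7 cells (Homo sapiens) for antiproliferative activity, read by MTT assay, with a stated time of 72 h; a higher number here means a weaker inhibitor, a lower number a stronger inhibitor
Compound 1 (`Clc1ccc(C2CC(c3ccc(N4CCCCC4)cc3)=NN2c2nc(-c3ccccc3)cs2)cc1`) gives 28400 nM
Compound 2 (`Clc1ccc(-c2csc(N3N=C(c4ccc(N5CCCCC5)cc4)CC3c3ccc(Cl)cc3)n2)cc1`) gives > 100000 nM

Compound 2 stands at > 100000 nM as a limit of the assay, not a number. Compound 3 (`FC(F)(F)c1ccc(-c2csc(N3N=C(c4ccc(N5CCCCC5)cc4)CC3c3ccc(Cl)cc3)n2)cc1`) carries trifluoromethyl in place of chloro on an aromatic carbon, para to a large group. Among the measured compounds shown here, one measured step bears on this: chloro in place of hydrogen gave an at least 3.5-fold higher number from compound 1 to compound 2 (0.54 log units; beyond the scatter) in that same assay, beyond the scatter. That step from compound 1 to compound 2 offers only a loose guide, so no shift beyond the scatter is expected in this assay here. The expected step (a number no higher from compound 2 to compound 3 (the limit leaves the size open)) is therefore small. Compound 3 is estimated at 100000 nM (35000 nM to 300000 nM).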

Compound 3, half-maximal inhibitory concentration: 23700 nM
Compound 3: the middle estimate sits 4.2-fold (0.63 log units) above what was measured, and the stated range ends above it.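

Compound 2 gives only a limit of the assay, not a number: the limit of > 100000 nM in this assay, at which 1 of the 3 values shown sits.

In this assay, replacing chloro with trifluoromethyl on this aromatic carbon gives an at least 4.2-fold lower number from compound 2 to compound 3 (0.62 log units; beyond the scatter), so the substituent here can move the result in either direction. Trifluoromethyl in place of hydrogen gives a 1.2-fold lower number from compound 1 to compound 3 (0.08 log units; within the scatter), so this pair cannot be told apart, and the loss seen with chloro does not follow every replacement of hydrogen at this place.

On these data alone, whether an amine, a methoxy group or a carboxylic acid at this position would give a clearly lower number remains open.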